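Swapping methyl for chloro on an antiproliferative compound

The source may report more compounds than this note shows. Statements on the series, on what has been measured and on what is new or still open speak of the compounds shown alone.

compound 1 `Clc1ccnc(Nc2ccc3ccccc3n2)c1`: > 30000 nM (a limit)
compound 2 `Cc1ccnc(Nc2ccc3cccc(O)c3n2)c1`: 5840 nM

Among the compounds with values here, only two compounds have been measured so far, and only one of them has given an actual number. In a functional assay on PC-3 cells (Homo sapiens) for antiproliferative activity, read by MTT assay, with a stated time of 96 h (a higher number here means a weaker inhibitor of growth, a lower number a stronger inhibitor of growth), compound 2 gives 5840 nM, so it has no numerical neighbour against which it can be ranked. The other reading, for compound 1, is the limit of > 30000 nM in this assay, at which 1 of the 2 values shown sits. That reading is a limit of the assay and not a number.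

The next compound to be tested is compound 3 `Oc1cccc2ccc(Nc3cc(Cl)ccn3)nc12`. It keeps the core of compound 2 but carries chloro in place of methyl on an aromatic carbon of a six-membered aromatic ring with 1 nitrogen, meta to a large group and opposite the ring nitrogen (chloro in place of methyl on an aromatic carbon). Within the data shown here, no measured step in this assay shows what this exchange does, so no shift beyond the usual scatter is expected, in either direction, and the range is kept wide. The expected change is a 1.2-fold lower number from compound 2 to compound 3 (0.07 log units; within the scatter). For compound 3 the estimate is 5000 nM, with an expected range from 1500 nM to 20000 nM.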

Compound 3, concentration for 50% growth inhibition: 2810 nM
The estimate for compound 3 lay 1.8-fold (0.25 log units) above the measured number; the measured number falls inside the stated range.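

In this assay, chloro in place of methyl on an aromatic carbon, opposite the ring nitrogen, now has a measured effect: the exchange gives a 2.1-fold lower number from compound 2 to compound 3 (0.32 log units; beyond the scatter). Within the data shown here, this is the first evidence that this position responds to the group it carries, although the step is modest and rests on a single pair of compounds. With chloro held in that place, hydroxy in place of hydrogen on an aromatic carbon gives an at least 10-fold lower number from compound 1 to compound 3 (1.02 log units; beyond the scatter), so the change at the hydroxy position is printed as large where the change at the chloro position is printed as modest, and the true size of this step stays unknown because the reading for compound 1 is a limit and not a number: the limit of > 30000 nM in this assay, at which 1 of the 3 values shown sits.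

The compounds shown leave open whether the exchange of methyl for chloro would have a similar effect on a core without the hydroxy group. They also leave open what bromo, methoxy or an amine would do in the place now held by chloro, and whether a methoxy group or an amine could stand in for the hydroxy group.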